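The source may hold more compounds than are shown below. What is called first, only, known or untested is meant among the compounds shown, and "the series" means these compounds.

Measured so far in a functional assay on HEK293 cells for agonist activity at Bile acid receptor (Homo sapiens), read by a luciferase reporter; a higher number here means a larger maximal response, a lower number a smaller maximal response:
compound 1, `CC(C)c1onc(-c2c(Cl)cccc2Cl)c1COc1ccc(N(C)C(=O)c2ccc(C(=O)O)cc2)c(C(F)(F)F)n1`: 63%
compound 2, `Cc1nc(OCc2c(-c3c(Cl)cccc3Cl)noc2C(C)C)ccc1N(C)C(=O)c1ccc(C(=O)O)cc1`: 49%

Compound 1 gives the highest of the two numbers; the nearest is compound 2, reached by a number 14 percentage points lower from compound 1 to compound 2 (beyond the scatter), a change of methyl in place of trifluoromethyl on an aromatic carbon.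

Compound 3, `CC(C)c1onc(-c2c(Cl)cccc2Cl)c1COc1ccc(N(C)C(=O)c2cccc(C(=O)O)c2)c(C(F)(F)F)n1`, has not been measured. It differs from compound 1 as follows: 3-carboxyphenyl in place of 4-carboxyphenyl on a carbonyl carbon. For the measured compounds named here, no measured step touches the carboxyphenyl part; the only step on record concerns the substituent on the shared core, and its modest size says nothing about the position of the carboxylic acid. The expectation for compound 3 therefore rests on the value of compound 1 alone, with wide uncertainty.

Compound 3 is expected to reach 50%, within 25% to 75%, meaning an estimated a number 13 percentage points lower from compound 1 to compound 3 (beyond the scatter).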

Compound 3, largest response reached (reported as efficacy), in percent of the reference or control that the assay uses: 55%
Compound 3: the middle estimate sits 5 percentage points below what was measured; low and high end bracket the measured number.
By their numbers in this assay, from the lowest: compounds 2, 3 and 1 (each within the scatter of the next, the first and the last beyond it).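

Exchanging 4-carboxyphenyl for 3-carboxyphenyl on a carbonyl carbon whose other neighbour is the amide-type nitrogen gives, in this assay, a number 8 percentage points lower from compound 1 to compound 3 (within the scatter). Unlike the exchange of trifluoromethyl for methyl on the shared core, a number 14 percentage points lower from compound 1 to compound 2 (beyond the scatter), this change in the carboxyphenyl part cannot be told apart from repeat scatter, so the two carboxyphenyl groups serve equally well in this read-out within the compounds shown. Nothing available explains why these two groups give matching responses.

Open, from the compounds shown here alone, is what a tetrazole or a primary carboxamide would give in place of the carboxylic acid on this ring. Also open, going by these compounds, is whether 3-carboxyphenyl would match 4-carboxyphenyl in the same way on the methyl-bearing core of compound 2.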